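The source may report more compounds than this note shows. Statements on the series, on what has been measured and on what is new or still open speak of the compounds shown alone.

Working notes on an ADME assay (liver) for metabolic stability, with Liver microsome (Rattus norvegicus) as the target, using microsomes and NADPH, with a stated time of 30 min, tested at 1 uM (a lower number here means slower removal, a higher number faster removal of the compound), follow. Compound 1 (`Nc1ccc(S(=O)(=O)N2CCN(c3ncc(C(O)(C(F)(F)F)C(F)(F)F)cc3C#CC3CC3)CC2)cn1`) gives 67 mL.min-1.g-1 here, compound 2 (`COCC#Cc1cc(C(O)(C(F)(F)F)C(F)(F)F)cnc1N1CCN(S(=O)(=O)c2ccc(N)nc2)CC1`) gives 399 mL.min-1.g-1 here, and compound 3 (`Nc1ccc(S(=O)(=O)N2CCN(c3ncc(C(O)(C(F)(F)F)C(F)(F)F)cc3-c3cccnc3)CC2)cn1`) gives 20 mL.min-1.g-1 here, the lowest of the three. Compound 4 (`Nc1ccc(S(=O)(=O)N2CCN(c3ncc(C(O)(C(F)(F)F)C(F)(F)F)cc3-c3ccc4sccc4c3)CC2)cn1`) carries 1-benzothiophen-5-yl in place of pyridin-3-yl on an aromatic carbon. Within the data shown here, two measured steps touch this position, the modest 3.4-fold lower number from compound 1 to compound 3 (0.53 log units; beyond the scatter) and the large 20-fold lower number from compound 2 to compound 3 (1.30 log units; beyond the scatter), and both end at pyridin-3-yl. A third, a 6.0-fold higher number from compound 1 to compound 2 (0.77 log units; beyond the scatter), changes only the alkyne substituent. Among the measured compounds shown here, no measured compound carries 1-benzothiophen-5-yl, so the evidence is indirect. With compound 3 at the bottom of the measured values, a modest upward move is expected, an estimated 3.5-fold higher number from compound 3 to compound 4 (0.54 log units; beyond the scatter) in this assay. Compound 4 is expected at 70 mL.min-1.g-1 (estimated range 25 mL.min-1.g-1 to 200 mL.min-1.g-1).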

Compound 4, intrinsic clearance in microsomes: 487 mL.min-1.g-1
For compound 4 the middle estimate is 7.0-fold (0.84 log units) below the measured one; measured number outside the range, above it.
By their numbers in this assay, from the lowest: compound 3; then compound 1; then compounds 2 and 4 (each within the scatter of the next).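

In this assay an aromatic ring at this position does not by itself keep the number low: 1-benzothiophen-5-yl in place of pyridin-3-yl gives a 24-fold higher number from compound 3 to compound 4 (1.39 log units; beyond the scatter). Measured against the alkynes, the same group gives a 1.2-fold higher number from compound 2 to compound 4 (0.09 log units; within the scatter), level with 3-methoxyprop-1-yn-1-yl, and a 7.3-fold higher number from compound 1 to compound 4 (0.86 log units; beyond the scatter) against 2-cyclopropylethynyl. Nothing in hand explains the jump.

Still open, on these data alone, is whether the low number of compound 3 follows the ring nitrogen of pyridin-3-yl or its single ring. Phenyl or quinolin-3-yl at this position would separate the two.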